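Amide substituent changes on a bis-sulfonyl piperidine series

A few compounds are considered here, and "the series" means these few. Any claim that something is new, unique, unknown or untested is made for them only; others in the source may bear on it.

Measured so far:
compound 1, `CCN(CC)S(=O)(=O)c1ccc(S(=O)(=O)N2CCC[C@@H](C(=O)N3CCC(F)(F)CC3)C2)cc1`, 16 nM
compound 2, `CCN(CC)S(=O)(=O)c1ccc(S(=O)(=O)N2CCC[C@@H](C(=O)N3CCC(O)CC3)C2)cc1`, 870 nM
compound 3, `CCN(CC)S(=O)(=O)c1ccc(S(=O)(=O)N2CCC[C@@H](C(=O)NC3COC3)C2)cc1`, 2340 nM

All three share one core and differ only in the group on the carbonyl carbon. In a functional assay on MIA PaCa-2 cells (Homo sapiens) for inhibition, read by MTT assay, with a stated time of 7 days (on this read-out lower numbers stand for stronger inhibition and higher numbers for weaker inhibition), compound 1 gives 16 nM, the lowest number of the set. Compound 3 stands highest: a 150-fold higher number from compound 1 to compound 3 (2.17 log units; beyond the scatter), and a 2.7-fold higher number from compound 2 to compound 3 (0.43 log units; beyond the scatter). The intermediate case, a 54-fold higher number from compound 1 to compound 2 (1.74 log units; beyond the scatter), shows that the group on the carbonyl carbon moves the read-out across a wide span.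

Compound 4, `CCN(CC)S(=O)(=O)c1ccc(S(=O)(=O)N2CCC[C@@H](C(=O)N[C@H]3CC[C@H](OC)CC3)C2)cc1`, is not yet measured. It differs from compound 3 as follows: 4-methoxycyclohexyl in place of oxetan-3-yl on an amide-type nitrogen. Going by the values given here, no measured step covers a carbocyclic ring on an amide-type nitrogen, so the bearing steps are only those from compound 1 and compound 2 to compound 3, both beyond the scatter. A six-membered ring substituted at the far position echoes the two piperidinyl amides, which gave lower numbers than compound 3. A decrease beyond the scatter is therefore expected for compound 4, of moderate size, a 3.9-fold lower number from compound 3 to compound 4 (0.59 log units; beyond the scatter), with wide uncertainty. In this assay compound 4 is estimated at 600 nM, between 120 nM and 3000 nM.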

Compound 4, half-maximal inhibitory concentration: 1350 nM
Compound 4: middle estimate off by 2.3-fold (0.35 log units), on the low side; the range from low to high includes it.
By their numbers in this assay, from the lowest: compound 1; then compounds 2, 4 and 3 (each within the scatter of the next, the first and the last beyond it).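

In this assay, 4-methoxycyclohexyl in place of oxetan-3-yl on the amide-type nitrogen gives a 1.7-fold lower number from compound 3 to compound 4 (0.24 log units; within the scatter), so going from 4 heavy atoms to 8 and from a four-membered ring with 1 hetero atom to a six-membered ring of carbon only does not move the read-out beyond the scatter. Compound 4 also cannot be told apart from the 4-hydroxypiperidin-1-yl amide, with a 1.6-fold higher number from compound 2 to compound 4 (0.19 log units; within the scatter), yet an 84-fold higher number from compound 1 to compound 4 (1.93 log units; beyond the scatter), so among the compounds shown a six-membered ring alone does not go with the low number, which only the 4,4-difluoropiperidin-1-yl group gives. No measured evidence bears on this result.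

Still open, as far as these compounds go, is whether that low number follows the two fluorines or the ring nitrogen on the carbonyl carbon. Plain piperidin-1-yl and (4,4-difluorocyclohexyl)amino on the carbonyl carbon would separate the two.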